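Methyl for Isopropyl: A Smaller Group on the Core

A few compounds are considered here, and "the series" means these few. Any claim that something is new, unique, unknown or untested is made for them only; others in the source may bear on it.

Compound 1, `CC(C)c1cc(N)c2cc(NC(=O)/C=C/c3ccc(C(F)(F)F)cc3)ccc2n1`: 2.1 nM
Compound 2, `CCCc1cc(N)c2cc(NC(=O)/C=C/c3ccc(Br)cc3)ccc2n1`: 4 nM

Both compounds were tested in an assay on isolated protein for displacement of a labelled ligand from melanin-concentrating hormone receptor 1 (Homo sapiens); on this read-out higher numbers stand for weaker inhibition and lower numbers for stronger inhibition. Compound 1 has the lowest number of the two, yet compound 2 lies within the scatter of it, so no order between them can be claimed. Compound 3, `Cc1cc(N)c2cc(NC(=O)/C=C/c3ccc(C(F)(F)F)cc3)ccc2n1`, differs from compound 1 by methyl in place of isopropyl on an aromatic carbon. Within the data shown here, no pair of measured compounds shows this change, so its effect is unknown. The expected step is a modest rise in the number, beyond the scatter, a 2.4-fold higher number from compound 1 to compound 3 (0.38 log units; beyond the scatter). Compound 3 is estimated at 5 nM, within a range from 1.5 nM to 15 nM.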

Compound 3, half-maximal inhibitory concentration: 8 nM
Estimate against measurement, compound 3: 1.6-fold (0.20 log units) below; the range from low to high includes it.
By their numbers in this assay, from the lowest: compounds 1, 2 and 3 (each within the scatter of the next, the first and the last beyond it).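

Methyl in place of isopropyl, next to the ring nitrogen, gives the first direct reading of this position: in this assay the change brings a modest loss, a 3.8-fold higher number from compound 1 to compound 3 (0.58 log units; beyond the scatter). The position is therefore sensitive to this change, though the loss is not large, and compound 3 still gives 8 nM in the same assay. No available evidence bears on the origin of this step.

Open, on these data alone, is how an ethyl or tert-butyl group would read at this position. A cyclopropyl ring or an amine there is equally unresolved.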